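The source may report more compounds than this note shows. Statements on the series, on what has been measured and on what is new or still open speak of the compounds shown alone.

Measured so far in a functional assay on DLD-1 cells (Homo sapiens) for cytotoxicity, read by XTT assay; on this read-out lower numbers stand for stronger inhibition and higher numbers for weaker inhibition:
- Compound 1 `C/C(=C\[C@@H](O)C/C(C)=C/CCCC(=O)CO)CC[C@@H](O)[C@]1(C)CCC(=O)O1`: > 20000 nM, a limit of the assay and not a number
- Compound 2 `CC(=O)O[C@H](CC/C(C)=C/[C@@H](O)C/C(C)=C/CCc1ccoc1)[C@]1(C)CCC(=O)O1`: 30 nM

Only one of these two results is a true number, so compound 2 at 30 nM is the single firm reference point in this assay.

Compound 3 `CC(=O)O[C@H](/C=C(\C)CC[C@@H](OC(C)=O)[C@]1(C)CCC(=O)O1)C/C(C)=C/CCc1ccoc1` has not yet been measured. It differs from compound 2 in one place: acetyl in place of hydrogen on an oxygen on a saturated carbon. Put simply, this is hydroxy to acetoxy, with acetyl in place of hydrogen on an oxygen on a saturated carbon. Among the compounds with values here, no measured pair shows what such a change does, so any expectation is loose. A modest weakening in this assay seems most likely, starting from compound 2 at 30 nM. The expected change is a 2.0-fold higher number from compound 2 to compound 3 (0.30 log units; within the scatter). The estimate for compound 3 is 60 nM, with an expected range of 12 nM to 400 nM.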

Compound 3, half-maximal inhibitory concentration: 600 nM
Estimate against measurement, compound 3: 10-fold (1.00 log units) below; measured number above the stated range.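

In this assay the change from hydroxy to acetoxy gives a 20-fold higher number from compound 2 to compound 3 (1.30 log units; beyond the scatter) and so counts as a real loss of strength, not a small adjustment. Within the data shown here, this is the first pair that differs in one place only, and it shows that this oxygen on a saturated carbon is not a spot where any change goes unnoticed: the form with the free hydroxy is clearly the stronger of the two. Nothing in the data shown explains why the acetyl costs this much.

One pair cannot say whether the loss comes from removing the hydrogen on this oxygen or from the size of the acetyl. A methyl ether at this place, or a longer acyl chain such as butyryl, would help to tell these two readings apart.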